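The compounds below may be only part of what the source reports. "The series", "measured", "known", "first", "only" and "open" are said of these compounds alone.

Compound 2 `O=C(O)c1cnc2cc(O)ccc2c1O` gives 955000 nM in an assay on isolated protein with malate dehydrogenase, cytoplasmic (Sus scrofa) as the target (on this read-out higher numbers stand for weaker inhibition and lower numbers for stronger inhibition), and stands between its two neighbours: compound 1 `O=C(O)c1cnc2cc(S(=O)(=O)O)ccc2c1O` gives 3090000 nM, while compound 3 `O=C(O)c1cnc2cc(OCCc3ccccc3)ccc2c1O` gives 155000 nM. Among the compounds with values here, the only single-place step seen so far runs from compound 1 to compound 2, a hydroxy in place of sulfo on an aromatic carbon. Compound 4 `NC(=O)c1ccc2c(O)c(C(=O)O)cnc2c1` alters that same carbon once more: carbamoyl in place of hydroxy on an aromatic carbon, on an aromatic carbon of a six-membered aromatic ring of carbon only, part of a fused system of two rings, meta to a fused ring and para to a fused ring. Within the data shown here, because a 3.2-fold lower number from compound 1 to compound 2 (0.51 log units; beyond the scatter) was modest and is the sole step bearing on this change, a step of similar size or none beyond the scatter is expected in this assay, leaning toward a lower number. Compound 4 is therefore estimated at 700000 nM, between 200000 nM and 2500000 nM, with a 1.4-fold lower number from compound 2 to compound 4 (0.13 log units; within the scatter) expected.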

Compound 4, half-maximal inhibitory concentration: 603000 nM
Estimate against measurement, compound 4: 1.2-fold (0.06 log units) above; the range from low to high includes it.
By their numbers in this assay, from the lowest: compound 3; then compounds 4 and 2 (each within the scatter of the next); then compound 1.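

In this assay, carbamoyl in place of hydroxy on this aromatic carbon gives (a 1.6-fold lower number from compound 2 to compound 4 (0.20 log units; within the scatter)), so the two groups are not told apart at this position. Carbamoyl in place of sulfo gives (a 5.1-fold lower number from compound 1 to compound 4 (0.71 log units; beyond the scatter)), which makes carbamoyl the second group, after hydroxy, to read clearly lower than sulfo here. Nothing available speaks to why these numbers fall as they do. Still open, going by these compounds, is whether an amine or a nitrile on the same carbon would read with hydroxy and carbamoyl or with sulfo.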